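Extending the ether chain on a nitrile-bearing receptor agonist

The source may report more compounds than this note shows. Statements on the series, on what has been measured and on what is new or still open speak of the compounds shown alone.

Compound 1 `COc1cc(-c2nc(-c3ccc(CCC(=O)O)cc3C)no2)ccc1OC(C)C`: 270 nM
Compound 2 `Cc1cc(CCC(=O)O)ccc1-c1noc(-c2ccc(OC(C)C)c(C#N)c2)n1`: 6.5 nM

Both compounds were tested in a functional assay on CHO cells for agonist activity at sphingosine 1-phosphate receptor 5 (Homo sapiens), read by GTPgammaS binding; on this read-out lower numbers stand for an effect already at smaller amounts and higher numbers for an effect only at larger amounts of compound. Compound 2 stands at the lowest number of the two, and its nearest neighbour, compound 1, lies far away: a 42-fold lower number from compound 1 to compound 2 (1.62 log units; beyond the scatter), a change of cyano in place of methoxy on an aromatic carbon.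

Compound 3 `CC[C@H](C)Oc1ccc(-c2nc(-c3ccc(CCC(=O)O)cc3C)no2)cc1C#N` differs from compound 2 only by methyl in place of hydrogen on a saturated chain carbon, two bonds along the chain from an oxygen on an aromatic ring, that is, isopropoxy becomes sec-butoxy while the nitrile and everything else stay in place. Within the data shown here, no measured pair here touches that chain, so the one known step, between compound 1 and compound 2, offers no direct guide; it only shows that the shared core tolerates changes on this ring. A step of no more than the usual scatter is expected, in either direction, as a 1.1-fold lower number from compound 2 to compound 3 (0.03 log units; within the scatter). Compound 3 is therefore estimated at 6 nM in this assay, with a range from 1.8 nM to 20 nM.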

Compound 3, half-maximal effective concentration: 15 nM
Compound 3: the middle estimate sits 2.5-fold (0.40 log units) below what was measured; measured number inside the range.
By their numbers in this assay, from the lowest: compound 2; then compound 3; then compound 1.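

Adding one methyl to the ether chain, turning isopropoxy into sec-butoxy, gives a 2.3-fold higher number from compound 2 to compound 3 (0.36 log units; beyond the scatter) in this assay, so this chain carbon is not a silent position: even a single extra carbon here moves the number beyond the usual scatter. The move is modest, though, and much smaller than a 42-fold lower number from compound 1 to compound 2 (1.62 log units; beyond the scatter) on the same ring, so the larger sec-butyl group is tolerated at only a small cost. No measurement here explains the shift.

One step cannot show whether the number would keep rising with a longer chain such as n-pentyloxy, or how a ring such as cyclopentyloxy would behave on this oxygen. The mirror-image form of the sec-butoxy group also remains an open comparison.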